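Changing the Halogen Pattern on the Amide Nitrogen

The source may report more compounds than this note shows. Statements on the series, on what has been measured and on what is new or still open speak of the compounds shown alone.

Compound 1, `CCOC(=O)C1=Cc2ccccc2OC1(OCc1cn(-c2ccccc2)nn1)C(F)(F)F`: in a functional assay on HeLa cells (Homo sapiens) for inhibition, read by MTT assay, with a stated time of 24 h (on this read-out lower numbers stand for stronger inhibition and higher numbers for weaker inhibition), compound 1 gives only a limit, > 150000 nM.
Compound 2, `CCOC(=O)C1=Cc2ccccc2OC1(OCc1cn(CC(=O)Nc2ccccc2Br)nn1)C(F)(F)F`: in this assay compound 2 gives only a limit, > 150000 nM.

Both measured compounds therefore sit at the limit of > 150000 nM in this assay, at which 2 of the 2 values shown sit, and neither has a read number. Within the data shown here, the single comparison between them, a step that the two limits leave unreadable from compound 1 to compound 2, is unreadable for that reason: a change from one limit to the same limit tells nothing about direction or size. Compound 2 thus stands at the limit itself, with no position on a numeric scale.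

Compound 3, `CCOC(=O)C1=Cc2ccccc2OC1(OCc1cn(CC(=O)Nc2ccc(I)cc2Cl)nn1)C(F)(F)F`, differs from compound 2 by 2-chloro-4-iodophenyl in place of 2-bromophenyl on an amide-type nitrogen. Among the measured compounds shown here, no measured step bears on this change; the only step in hand touches another part of the molecule and is itself unreadable. With nothing pointing toward stronger inhibition, the expectation is that compound 3 will again return a limit rather than a number. Compound 3 is estimated at 150000 nM, within a range from 60000 nM to 400000 nM. The step this estimate implies, a number no higher from compound 2 to compound 3 (the limit leaves the size open), is expected to be none beyond the scatter.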

Compound 3, half-maximal inhibitory concentration: 26100 nM
Compound 3: the middle estimate sits 5.7-fold (0.76 log units) above what was measured; measured number outside the range, below it.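

Among these compounds, replacing 2-bromophenyl with 2-chloro-4-iodophenyl on the amide-type nitrogen gives the first readable number in this set, and in this assay the change is an at least 5.7-fold lower number from compound 2 to compound 3 (0.75 log units; beyond the scatter). On these data alone, this shows that the aryl group on this nitrogen is a place where a change can move the read-out, which could not be seen while every compound sat at the limit, and the step starts from a limit, so its full size stays open: the limit of > 150000 nM in this assay, at which 2 of the 3 values shown sit. The wider replacement of phenyl on the aromatic nitrogen gives an at least 5.7-fold lower number from compound 1 to compound 3 (0.75 log units; beyond the scatter), yet compound 2 carries the same carbamoylmethyl link and gives only a limit, so the link alone does not bring a readable number and the halogens on the ring matter.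

The change removes bromine and adds both chlorine and iodine at once, so the compounds shown cannot tell whether chlorine, iodine or the pair goes with the step. As far as these compounds go, how an amine, a nitrile or a carboxylic acid on that same phenyl ring would read in this assay also stays open.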